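The source may hold more compounds than are shown below. What is called first, only, known or untested is meant among the compounds shown, and "the series" means these compounds.

Compound 1, `CCc1cc(Cl)c(S(C)(=O)=O)cc1C(=O)N=C(N)N`, gives 63 nM in a functional assay for inhibition of sodium/hydrogen exchanger (Oryctolagus cuniculus); on this read-out higher numbers stand for weaker inhibition and lower numbers for stronger inhibition.
Compound 2, `Cc1c(C(=O)N=C(N)N)ccc(Cl)c1S(C)(=O)=O`, gives 1300 nM in this assay.
Compound 3, `CCc1cc(C)c(C(=O)N=C(N)N)cc1S(C)(=O)=O`, gives 4.8 nM in this assay.

Of the three measured compounds, compound 3 stands at the lowest number in this assay. Its nearest neighbour is compound 1, whose number lies above it by a margin beyond the usual scatter, and compound 2 lies further away still, also beyond the scatter. Compound 3 is therefore the strongest inhibitor among the three.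

Compound 4, `Cc1cc(-c2ccco2)c(S(C)(=O)=O)cc1C(=O)N=C(N)N`, has not yet been measured. It differs from compound 3 in a single place: furan-2-yl in place of ethyl on an aromatic carbon. For the measured compounds named here, no measured pair in this set shows what such an exchange of an ethyl for a furan-2-yl does on this core, so the expectation rests on the standing of compound 3 alone. A step from compound 3 to compound 4 of modest size toward weaker inhibition is expected, a 3.1-fold higher number from compound 3 to compound 4 (0.49 log units; beyond the scatter), with a wide range around it. Compound 4 is estimated at 15 nM, between 3 nM and 80 nM.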

Compound 4, half-maximal inhibitory concentration: 16 nM
The estimate for compound 4 lay 1.1-fold (0.03 log units) below the measured number; low and high end bracket the measured number.
By their numbers in this assay, from the lowest: compound 3; then compound 4; then compound 1; then compound 2.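

On the aromatic carbon ortho to the methylsulfonyl group and meta to the methyl group, furan-2-yl in place of ethyl gives a 3.3-fold higher number from compound 3 to compound 4 (0.52 log units; beyond the scatter) in this assay and so costs only a modest part of the inhibition. This position therefore accepts a five-membered aromatic ring of 5 heavy atoms in place of a chain of 2, and compound 4 still stands at 16 nM on the shared core. Nothing at hand says what lies behind this step.

On these data alone, a single exchange cannot separate the weight of the ring from that of its oxygen, so the effect of a phenyl, a thiophen-2-yl or a longer chain such as propyl on this carbon remains open. As far as these compounds go, whether an amine would be accepted here also remains open.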